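A few compounds are considered here, and "the series" means these few. Any claim that something is new, unique, unknown or untested is made for them only; others in the source may bear on it.

Of the compounds shown here, three built on the same core have been tested in a functional assay on HT-29 cells (Homo sapiens) for antiproliferative activity, read by MTT assay, with a stated time of 48 h; a lower number here means a stronger inhibitor of growth, a higher number a weaker inhibitor of growth. Compound 1 `Fc1ccc(C2=NN(C(=S)Nc3ccccc3)C(c3ccc4c(c3)OCCO4)C2)cc1` gives 37600 nM; compound 2 `COc1ccccc1C1=NN(C(=S)Nc2ccccc2)C(c2ccc3c(c2)OCCO3)C1` gives 30500 nM; compound 3 `Cc1ccc(C2=NN(C(=S)Nc3ccccc3)C(c3ccc4c(c3)OCCO4)C2)cc1C` gives 133000 nM. Among these three numbers compound 1 stands second highest: its nearest neighbour is compound 2, its furthest is compound 3.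

The steps between them all change the aryl group on the carbon with a double bond to nitrogen. The swap to a 2-methoxyphenyl gives a 1.2-fold lower number from compound 1 to compound 2 (0.09 log units; within the scatter), the swap to a 3,4-dimethylphenyl gives a 3.5-fold higher number from compound 1 to compound 3 (0.55 log units; beyond the scatter) and a 4.4-fold higher number from compound 2 to compound 3 (0.64 log units; beyond the scatter).

Compound 4 `S=C(Nc1ccccc1)N1N=C(c2ccc(OCc3ccccc3)cc2)CC1c1ccc2c(c1)OCCO2` differs from compound 1 by benzyloxy in place of fluoro on an aromatic carbon, on the same aryl group. For the measured compounds named here, no measured step introduces a benzyloxy, so the three known steps bear only loosely on it; they show that changes at this ring moved this assay by at most a modest amount. The expected step is therefore a 1.1-fold lower number from compound 1 to compound 4 (0.03 log units; within the scatter), with no firm direction. Compound 4 is estimated at 35000 nM, within a range from 10000 nM to 120000 nM.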

Compound 4, concentration for 50% growth inhibition: 860 nM
Compound 4: middle estimate off by 41-fold (1.61 log units), on the high side, and the stated range ends above it.
By their numbers in this assay, from the lowest: compound 4; then compounds 2 and 1 (each within the scatter of the next); then compound 3.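

The step of a 44-fold lower number from compound 1 to compound 4 (1.64 log units; beyond the scatter) in this assay is far larger than any step among the first three compounds, so this place on the ring can change growth inhibition much more than those smaller swaps suggested. The change adds a second aromatic ring and an oxygen atom on an aromatic carbon, and a substituent this much larger than fluoro goes with the lowest number of the four compounds. Nothing measured here explains why this single change has so large an effect.

The compounds shown leave open whether the gain needs the whole benzyloxy group or only part of it, which a methoxy, a phenyl attached directly to the ring or a longer phenylpropoxy chain at the same place could help separate. They also leave open whether an amine or a carboxylic acid on the outer ring would keep the gain.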